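The source may hold more compounds than are shown below. What is called first, only, known or untested is meant among the compounds shown, and "the series" means these compounds.

Among the compounds with values here, compound 1 `ClCc1cccc(Cn2cnc3c(Cl)nc(Cl)nc32)c1` is the compound whose number stands lowest among the three measured so far in a functional assay on Hs-578T cells (Homo sapiens) for cytotoxicity, read by sulforhodamine B assay, with a stated time of 48 h; a higher number here means a weaker inhibitor of growth, a lower number a stronger inhibitor of growth. In this assay compound 1 gives 4360 nM. Compound 3 `ClCc1ccccc1Cn1cnc2c(Cl)ncnc21` gives 6600 nM in this assay, a number within the scatter of that of compound 1, so the two cannot be ordered. Compound 2 `Nc1nc(Cl)c2ncn(Cc3ccccc3CCl)c2n1` gives 77600 nM in this assay, well beyond the scatter from both. Within the data shown here, the one step between compounds that differ in a single place is a 12-fold lower number from compound 2 to compound 3 (1.07 log units; beyond the scatter).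

Compound 4 `ClCc1cccc(Cn2cnc3c(Cl)ncnc32)c1` has not yet been measured in this assay. It differs from compound 1 by hydrogen in place of chloro on an aromatic carbon. Among the measured compounds shown here, no measured step follows chloro to hydrogen; the step from compound 2 to compound 3 concerns an amino group and bears on compound 4 only indirectly. Compound 3 differs from compound 1 in two places, one of them this same change, and its value lies within the scatter of that of compound 1, which gives the only hint. The expected step is therefore a 1.3-fold higher number from compound 1 to compound 4 (0.10 log units; within the scatter), none beyond the scatter in either direction. Compound 4 is estimated at 5500 nM, in the range 2200 nM to 14000 nM.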

Compound 4, concentration for total growth inhibition: 11500 nM
Compound 4: middle estimate off by 2.1-fold (0.32 log units), on the low side; the measured number falls inside the stated range.
By their numbers in this assay, from the lowest: compounds 1, 3 and 4 (each within the scatter of the next, the first and the last beyond it); then compound 2.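

Hydrogen in place of chloro on the aromatic carbon between two ring nitrogen atoms can now be read directly on the core of compound 1, and in this assay this change gives a 2.6-fold higher number from compound 1 to compound 4 (0.42 log units; beyond the scatter). The step is modest, but it lies beyond the scatter and shows that the chloro group at this place makes a measurable difference, which the earlier comparison of compounds differing in two places could only hint at. Within the data shown here, the only earlier step that ends in hydrogen, a 12-fold lower number from compound 2 to compound 3 (1.07 log units; beyond the scatter), runs in the opposite direction, so in these two pairs the outcome of placing hydrogen depends on the group it replaces, although the two pairs carry the chloromethyl group at different places on the benzyl ring. Nothing available explains why the number moves with this change.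

On these data alone, it remains open how a fluoro, bromo, methoxy or methylamino group would compare with chloro at this place. As far as these compounds go, it is also open whether the chloro to hydrogen step would hold with the chloromethyl group placed as in compound 3.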